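Trifluoromethoxy in Place of Fluoro on a Shared Core

A few compounds are considered here, and "the series" means these few. Any claim that something is new, unique, unknown or untested is made for them only; others in the source may bear on it.

Compound 1, `Oc1ccccc1-c1cc(-c2ccccc2F)cc(-c2ccccc2O)n1`, in a functional assay on DU-145 cells (Homo sapiens) for inhibition (on this read-out lower numbers stand for stronger inhibition and higher numbers for weaker inhibition), gives only a limit of the assay: > 50000 nM.
Compound 2, `Oc1ccc(-c2cc(-c3ccccc3F)cc(-c3ccccc3O)n2)cc1`, in this assay gives likewise a limit: > 50000 nM.
Compound 3, `Oc1ccc(-c2cc(-c3ccc(F)cc3)cc(-c3ccccc3O)n2)cc1`, in this assay gives again a limit: > 50000 nM.

Compound 2 therefore stands nowhere in particular on these numbers: it has no measured value, only a limit, and the two other values shown are limits as well. The step that the two limits leave unreadable from compound 1 to compound 2 and the step that the two limits leave unreadable from compound 2 to compound 3 cannot be sized, because of the limit of > 50000 nM in this assay, at which 3 of the 3 values shown sit.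

Compound 4, `Oc1ccc(-c2cc(-c3ccccc3OC(F)(F)F)cc(-c3ccccc3O)n2)cc1`, differs from compound 2 by trifluoromethoxy in place of fluoro on an aromatic carbon. Among the measured compounds shown here, no measured step bears on this change in a readable way, so no direction can be taken from the neighbours. What the three limits do say is that small changes on the two outer rings have not yet brought any compound into the measurable range.

The expectation for compound 4 is therefore that it remains around the limit, with the step of a number no higher from compound 2 to compound 4 (the limit leaves the size open) expected to be no larger than the scatter. The estimated value for compound 4 is 50000 nM, within 15000 nM to 150000 nM.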

Compound 4, half-maximal inhibitory concentration: 4190 nM
Beside the measured number, compound 4's estimate is 12-fold (1.08 log units) above it, and the stated range ends above it.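

In this assay, trifluoromethoxy in place of fluoro on an aromatic carbon, ortho to a large group, gives an at least 11-fold lower number from compound 2 to compound 4 (1.07 log units; beyond the scatter). Among the compounds shown here, this position on the shared core therefore responds to the group it carries, which the earlier steps could not show, as none of them can be read. Compound 4 is the only compound shown that comes off the limit: the limit of > 50000 nM in this assay, at which 3 of the 4 values shown sit.

This single change swaps one heavy atom for five and adds one hydrogen-bond acceptor, so the compounds shown do not separate the part played by the oxygen from that of the fluorines; a methoxy or trifluoromethyl group at the same position would bear on that. From the compounds shown here alone, it also remains open whether trifluoromethoxy would have a similar effect with the 2-hydroxyphenyl group of compound 1 in place of the 4-hydroxyphenyl group.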